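Swapping a fluorophenyl for a thiophene ring

The source may report more compounds than this note shows. Statements on the series, on what has been measured and on what is new or still open speak of the compounds shown alone.

Measured compounds:
- compound 1 `O=Cc1ccc(-c2cn3ccnc3c(-c3ccc4ncn(C5CCCCC5)c4c3)n2)cc1`: 51.2%
- compound 2 `c1cn2cc(-c3ccsc3)nc(-c3ccc4ncn(C5CCCCC5)c4c3)c2n1`: 1.35%
- compound 3 `Fc1ccccc1-c1cn2ccnc2c(-c2ccc3ncn(C4CCCCC4)c3c2)n1`: 21.3%

In a functional assay on MDA-MB-231 cells (Homo sapiens) for inhibition, read by sulforhodamine B assay, with a stated time of 48 h, tested at 10 uM (on this read-out higher numbers stand for more inhibition at the one concentration tested (going by the name of the read-out) and lower numbers for less inhibition), compound 3 stands second highest of the three, with compound 2 nearest at a lower value and compound 1 furthest at a higher value. Compound 4 `c1csc(-c2cn3ccnc3c(-c3ccc4ncn(C5CCCCC5)c4c3)n2)c1` is not yet measured; it differs from compound 3 by thiophen-2-yl in place of 2-fluorophenyl on an aromatic carbon. Going by the values given here, one measured step bears on this change: a number 20 percentage points higher from compound 2 to compound 3 (beyond the scatter), a modest rise when a thiophene ring gave way to the 2-fluorophenyl. Compound 4 reverses that kind of change, though with thiophen-2-yl rather than thiophen-3-yl, so a modest fall beyond the scatter is expected for compound 4, roughly a number 13.3 percentage points lower from compound 3 to compound 4 (beyond the scatter). The estimate for compound 4 in this assay is therefore 8%, within 0% to 25%.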

Compound 4, a percentage reported as inhibition, at one concentration (the size of the read-out at that concentration, not a potency): 10.8%
Beside the measured number, compound 4's estimate is 2.8 percentage points below it; the range from low to high includes it.
By their numbers in this assay, from the lowest: compounds 2 and 4 (each within the scatter of the next); then compound 3; then compound 1.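

In this assay, where the thiophene ring is attached matters little here: a number 9.5 percentage points higher from compound 2 to compound 4 (within the scatter). Both thiophene compounds fall short of the two phenyl-bearing compounds, with a number 10.5 percentage points lower from compound 3 to compound 4 (beyond the scatter) and a number 40.4 percentage points lower from compound 1 to compound 4 (beyond the scatter). Nothing available explains these differences. From the compounds shown here alone, it remains open whether the formyl group on the phenyl ring accounts for the lead of compound 1, and whether an amine or a carboxylic acid in its place would match it.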